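The source may hold more compounds than are shown below. What is called first, only, known or untested is meant among the compounds shown, and "the series" means these compounds.

Measured compounds in the series:

- compound 1, `COc1ccccc1C(=O)NC(=O)Nc1ccc(-c2ccccc2)c(C(F)(F)F)c1`. In a physicochemical assay for solubility, in phosphate buffer, at pH 7.4 (a higher number here means a more soluble compound, a lower number a less soluble compound), compound 1 gives < 1 ug/mL, which is a limit of the assay and not a number.
- compound 2, `COc1ccccc1C(=O)NC(=O)Nc1ccc(-c2ccccc2)c(C(C)C)c1`. In this assay compound 2 gives < 1 ug/mL, again a limit of the assay.
- compound 3, `COc1ccccc1C(=O)NC(=O)Nc1ccc(-c2nccs2)c(C(F)(F)F)c1`. In this assay compound 3 gives < 1 ug/mL, also a limit of the assay.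

Compound 3 therefore stands at the limit, as do the two other values shown; nothing separates the three. The two measured steps, a step that the two limits leave unreadable from compound 1 to compound 2 and a step that the two limits leave unreadable from compound 1 to compound 3, cannot be read in size or direction, since both ends sit at the limit, as the limit of < 1 ug/mL in this assay, at which 3 of the 3 values shown sit, records.

The next compound, compound 4, `COc1ccccc1C(=O)NC(=O)Nc1ccc(OCC(F)(F)F)c(C(F)(F)F)c1`, differs from compound 3 in one place: 2,2,2-trifluoroethoxy in place of 1,3-thiazol-2-yl on an aromatic carbon. For the measured compounds named here, no measured step touches this change; the only bearing is that every value so far, including that of compound 3, sits at the limit, and neither of the steps already measured has moved a compound off it.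

The expectation for compound 4 in this assay is therefore a step of a number no lower from compound 3 to compound 4 (the limit leaves the size open) from compound 3, most likely again reported as a limit. The estimated value for compound 4 is 1 ug/mL, within a range from 0.3 ug/mL to 5 ug/mL.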

Compound 4, solubility: < 1 ug/mL
Compound 4: a limit, no number (the forecaster's own chance of this, stated with the estimate: 65%); the middle value lies on the limit itself.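

In this assay compound 4 gives < 1 ug/mL, a limit of the assay and not a number. No new step can be read from compound 3 or compound 1 to compound 4, because both ends of each pair sit at: the limit of < 1 ug/mL in this assay, at which 4 of the 4 values shown sit.

The compounds shown leave open what the actual solubility of any of the four is, and which change to the shared core would give a readable value in this assay.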